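Methyl for Hydrogen on Two Different Side Chains

A few compounds are considered here, and "the series" means these few. Any claim that something is new, unique, unknown or untested is made for them only; others in the source may bear on it.

Three compounds have been measured in a functional assay on the whole organism with Rattus norvegicus as the target, with a stated time of 4 h, at a dose of 40 mg/kg by the intraperitoneal route; a higher number here means more inhibition at the dose given (going by the name of the read-out), a lower number less inhibition:

Compound 1, `COCc1c(C)nc2c(OCc3ccccc3)cccn12`, gives 99%.
Compound 2, `CCOCc1c(C)nc2c(OCc3ccccc3)cccn12`, gives 84%.
Compound 3, `Cc1nc2c(OCc3ccccc3)cccn2c1C`, gives 99%.

Compound 1 and compound 3 share a core and differ by hydrogen in place of methoxy on a saturated chain carbon bound to an aromatic carbon; in this assay that difference made no change at the digits printed from compound 1 to compound 3 (within the scatter), so the two sit together at the top of the three numbers. Compound 2 differs from compound 1 by methyl in place of hydrogen on a saturated chain carbon bound to an oxygen on a saturated carbon, and this step made a number 15 percentage points lower from compound 1 to compound 2 (beyond the scatter), a drop beyond the usual scatter. Compound 2 also differs from compound 3, and that step made a number 15 percentage points higher from compound 2 to compound 3 (beyond the scatter).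

The unmeasured compound 4, `CCc1nc2c(OCc3ccccc3)cccn2c1C`, differs from compound 3 by methyl in place of hydrogen on a saturated chain carbon bound to an aromatic carbon. This is the same kind of change as from compound 1 to compound 2, but not the same: there the methyl entered on a saturated chain carbon bound to an oxygen on a saturated carbon, here it enters on a saturated chain carbon bound to an aromatic carbon. Compound 3 already stands near the top of the scale, so little room for a rise remains, and a modest fall is the more likely outcome because a number 15 percentage points lower from compound 1 to compound 2 (beyond the scatter) was a modest fall for the same kind of change. The step from compound 3 to compound 4 is therefore estimated at a number 9 percentage points lower from compound 3 to compound 4 (within the scatter). Compound 4 is expected to give about 90%, with a likely range from 72% to 100%.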

Compound 4, a percentage reported as inhibition, in the whole organism at one dose (the size of the read-out at that dose, not a potency): 79%
The estimate for compound 4 lay 11 percentage points above the measured number; the range from low to high includes it.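

In this assay, putting methyl in place of hydrogen on a saturated chain carbon bound to an aromatic carbon gave a number 20 percentage points lower from compound 3 to compound 4 (beyond the scatter) and so counts as a modest fall. Going by these compounds alone, this rests on only two pairs of compounds, read at one dose in one assay, and the methyl sits at a different place in each pair, on a carbon bound to an oxygen in one and on a carbon bound to an aromatic carbon in the other; it does not show that the fall would recur on a further core, and it says nothing about why the number drops. Within those limits, adding one methyl to the side chain carried over from one core to the other in the same direction and with much the same size: the same change on two cores in this assay, a number 15 percentage points lower (beyond the scatter) from compound 1 to compound 2 and a number 20 percentage points lower (beyond the scatter) from compound 3 to compound 4, 5 percentage points apart, within the scatter of two such steps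

The compounds shown leave open how a longer chain such as propyl, or a different group such as an amine or a carboxylic acid, would read on this side chain. They also leave open whether the two methyl steps would still agree at another dose or another time point, where the numbers might sit further from the top of the scale.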